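The compounds below may be only part of what the source reports. "The series", "measured", "known", "first", "only" and "open" are said of these compounds alone.

Compound 1 `O=c1oc2ccccc2c(O)c1C(c1ccc(F)c(F)c1)c1c(O)c2ccccc2oc1=O` carries a 3,4-difluorophenyl group on a saturated chain carbon bound to two aromatic carbons. In a functional assay on HuTu80 cells (Homo sapiens) for antiproliferative activity, read by MTT assay, with a stated time of 48 h (a higher number here means a weaker inhibitor, a lower number a stronger inhibitor), compound 1 gives 15 ug/mL, the lowest of the three numbers recorded. Compound 3 `N#CC1=C(N)OC2=C(C(=O)CC2)C1c1ccc(Cl)cc1Cl` gives 150 ug/mL in this assay, and compound 2 `COc1cccc(C2C(C#N)=C(N)OC3=C2C(=O)CC(C)(C)C3)c1` gives 283 ug/mL; both gaps to compound 1 lie beyond the usual scatter, so compound 1 is the strongest inhibitor of the three. Compounds 2 and 3 share neither the core of compound 1 nor its aryl substituent, so they say nothing directly about what a change on that chain carbon does.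

Compound 4 `N#Cc1ccc(C(c2c(O)c3ccccc3oc2=O)c2c(O)c3ccccc3oc2=O)cc1` is the next compound to be measured in this assay. It differs from compound 1 in one place: 4-cyanophenyl in place of 3,4-difluorophenyl on a saturated chain carbon bound to two aromatic carbons. Among the measured compounds shown here, no pair of measured compounds shows the effect of such an exchange, so the expectation rests on the unchanged core of compound 1 alone. The step of a 1.3-fold higher number from compound 1 to compound 4 (0.12 log units; within the scatter) from compound 1 to compound 4 is expected to be small, with no firm direction, and quite possibly within the scatter. Compound 4 is therefore estimated to give about 20 ug/mL in this assay, with a plausible range from 8 ug/mL to 50 ug/mL.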

Compound 4, half-maximal inhibitory concentration: 47.6 ug/mL
Compound 4: middle estimate off by 2.4-fold (0.38 log units), on the low side; the measured number falls inside the stated range.
By their numbers in this assay, from the lowest: compound 1; then compound 4; then compounds 3 and 2 (each within the scatter of the next).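

Among the compounds shown here, the exchange of 3,4-difluorophenyl for 4-cyanophenyl on a saturated chain carbon bound to two aromatic carbons gives the first reading of this position: in this assay there is a 3.2-fold higher number from compound 1 to compound 4 (0.50 log units; beyond the scatter) on the unchanged core of compound 1. So the aryl group at this place does affect the number, though the step is modest, and compound 4 remains on the same side of the comparison as a compound with a usable number well short of compounds 2 and 3, which differ in more than one place and cannot be set against it. The two groups match in heavy-atom count and in their one six-membered aromatic ring of carbon only, while the entering group adds a triple bond and a hydrogen-bond acceptor and the fluorine atoms leave, but nothing measured here says which of these differences matters.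

As far as these compounds go, a single exchange sets no trend, so it remains open how a plain phenyl, a methoxy group, an amine or a carboxylic acid on that ring would compare. From the compounds shown here alone, it is also open whether any group at this place would give a lower number than compound 1 does.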